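Chalcone aryl swap: naphthalenyl for trimethoxyphenyl at compound 3

The source may report more compounds than this note shows. Statements on the series, on what has been measured and on what is new or still open speak of the compounds shown alone.

Two compounds in the series carry the same core and differ only in the aryl group on the chalcone chain. Compound 1 `COc1cc(OC)c(/C=C/C(=O)c2ccc(Nc3cc(C)nc4nc(SCc5nc6ccccc6[nH]5)nn34)cc2)c(OC)c1` gives 260 nM in a functional assay on SW-620 cells (Homo sapiens) for cytotoxicity, read by MTT assay, with stated times of 4 h and 72 h, tested at 1 uM; a lower number here means a stronger inhibitor, a higher number a weaker inhibitor. Compound 2 `COc1cc(/C=C/C(=O)c2ccc(Nc3cc(C)nc4nc(SCc5nc6ccccc6[nH]5)nn34)cc2)cc(OC)c1OC` gives 75 nM in this assay, the lowest of the two numbers; the change a 3.5-fold lower number from compound 1 to compound 2 (0.54 log units; beyond the scatter) shows that the substitution pattern of the aryl group at this place moves the number beyond the scatter. Compound 3 `Cc1cc(Nc2ccc(C(=O)/C=C/c3ccc4ccccc4c3)cc2)n2nc(SCc3nc4ccccc4[nH]3)nc2n1` is not yet measured in this assay. Relative to compound 2 it carries naphthalen-2-yl in place of 3,4,5-trimethoxyphenyl on a double-bonded chain carbon bound to a double-bonded chain carbon. For the measured compounds named here, the one measured step bears on it only in showing that this position is sensitive, and gives no direction for removing all three methoxy groups in favour of a second carbon ring. A modest rise in number from compound 2 to compound 3 is therefore expected, a 2.9-fold higher number from compound 2 to compound 3 (0.47 log units; beyond the scatter), with wide uncertainty. Compound 3 is estimated at 220 nM in this assay, within 60 nM to 800 nM.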

Compound 3, half-maximal inhibitory concentration: 28.2 nM
For compound 3 the middle estimate is 7.8-fold (0.89 log units) above the measured one; measured number outside the range, below it.
By their numbers in this assay, from the lowest: compound 3; then compound 2; then compound 1.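

In this assay the aryl group on a double-bonded chain carbon bound to a double-bonded chain carbon needs no methoxy groups to reach the lowest number of the three: the naphthalen-2-yl swap gives a 2.7-fold lower number from compound 2 to compound 3 (0.42 log units; beyond the scatter) and, against the less favourable trimethoxy pattern, a 9.2-fold lower number from compound 1 to compound 3 (0.96 log units; beyond the scatter) as well. The earlier pair showed only that moving the three methoxy groups around the ring shifts the number, whereas this change removes all three hydrogen-bond acceptors of the group and adds a second six-membered aromatic ring, and the number still falls. No supporting data bear on why the number falls.

As far as these compounds go, the second ring and the loss of the methoxy groups arrive together here, so their separate contributions remain open. A plain phenyl, a naphthalen-1-yl or a phenyl carrying a single methoxy group would help to separate them.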